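The source may report more compounds than this note shows. Statements on the series, on what has been measured and on what is new or still open speak of the compounds shown alone.

Three compounds of the series have so far been run in an ADME assay on MRC5 cells (Homo sapiens) for cytotoxicity, read by MTT assay, with a stated time of 48 h; a lower number here means a stronger inhibitor, a higher number a weaker inhibitor. Compound 1 `COC(=O)c1ccc2[nH]cc(C3(c4c[nH]c5ccc(C(=O)OC)cc45)C(=O)Nc4ccccc43)c2c1` gives only a limit there, > 100000 nM. Compound 3 `COC(=O)c1ccc2[nH]cc(C3(c4c[nH]c5ccc(C(=O)OC)cc45)C(=O)Nc4ccc(Cl)cc43)c2c1` likewise gives only a limit in this assay, > 100000 nM. Compound 2 `O=C1Nc2ccc(Cl)cc2C1(c1c[nH]c2ccc(Br)cc12)c1c[nH]c2ccc(Br)cc12` also gives only a limit, > 100000 nM. All three measured values thus sit at the limit of > 100000 nM in this assay, at which 3 of the 3 values shown sit, and the step that the two limits leave unreadable from compound 3 to compound 1 cannot be read, the change being (hydrogen in place of chloro on an aromatic carbon). Compound 4 `O=C1Nc2ccccc2C1(c1c[nH]c2ccc(Br)cc12)c1c[nH]c2ccc(Br)cc12` has not yet been measured in this assay. The difference between the core of compound 2 and the core of compound 3 is not broken down here. Compound 4 differs from compound 2 by hydrogen in place of chloro on an aromatic carbon, the same change as from compound 3 to compound 1, at a place described in the same words. The earlier instance of this change runs between two limits and has no readable size. The expectation for compound 4 rests only on every measured value sitting at the limit of > 100000 nM in this assay, at which 3 of the 3 values shown sit. For compound 4 the expected step is a step that the limit leaves unreadable from compound 2 to compound 4. Compound 4 is estimated at 150000 nM, within 60000 nM to 400000 nM, most likely again reported only as a limit.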

Compound 4, half-maximal inhibitory concentration: > 100000 nM
Compound 4 gave a limit, no number (the forecaster's own chance of this, stated with the estimate: 85%); the middle value is on the limit's open side.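

Compound 2 and compound 4 each give only a limit, so the step between them, hydrogen in place of chloro on an aromatic carbon, cannot be read. The compounds shown leave open how large this change is in this assay, and whether it has any size there, with every value so far a limit: the limit of > 100000 nM in this assay, at which 4 of the 4 values shown sit.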